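Chloro substituent on a sulfonamide-indole scaffold: second placement

The source may report more compounds than this note shows. Statements on the series, on what has been measured and on what is new or still open speak of the compounds shown alone.

Measured compounds in a functional assay on KB cells (Homo sapiens) for antiproliferative activity, read by colorimetric assay and MTT assay; a lower number here means a stronger inhibitor, a higher number a weaker inhibitor:
compound 1 `COc1ccc(S(=O)(=O)Nc2cccc3cc[nH]c23)cc1` gives 0.67 ug/mL
compound 2 `COc1ccc(S(=O)(=O)Nc2ccc(Cl)c3cc[nH]c23)cc1` gives 0.92 ug/mL
compound 3 `O=[N+]([O-])c1ccc(S(=O)(=O)Nc2cccc3cc[nH]c23)cc1` gives 15 ug/mL

The three measured compounds share a sulfonamide that links a substituted benzene to an indole. Compound 1 and compound 3 differ in the group on the benzene ring: nitro in place of methoxy on an aromatic carbon. That exchange produced the one large movement in this set, a 22-fold higher number from compound 1 to compound 3 (1.35 log units; beyond the scatter), and compound 3 therefore has the highest number of the three, beyond the scatter of both others.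

Compound 2 arises from compound 1 by chloro in place of hydrogen on an aromatic carbon. The step is small, a 1.4-fold higher number from compound 1 to compound 2 (0.14 log units; within the scatter), so the two values are not distinguished by this assay.

Compound 4 `O=[N+]([O-])c1ccc(S(=O)(=O)Nc2cccc3cc(Cl)[nH]c23)cc1` has not been measured. It arises from compound 3 by chloro in place of hydrogen on an aromatic carbon. This is the same kind of change as from compound 1 to compound 2, but not the same: there the chloro sits on an aromatic carbon of a six-membered aromatic ring of carbon only, ortho to a fused ring, meta to a fused ring and para to a large group, whereas here it sits on an aromatic carbon of a five-membered aromatic ring with one nitrogen, next to the ring nitrogen. Among the measured compounds shown here, the only precedent therefore concerns a different position, and on a core without the nitro group of compound 3.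

For the measured compounds named here, the step from compound 3 to compound 4 is expected to be small, a 1.1-fold higher number from compound 3 to compound 4 (0.03 log units; within the scatter), resting on the single precedent in which the chloro change gave a 1.4-fold higher number from compound 1 to compound 2 (0.14 log units; within the scatter). Compound 4 is accordingly estimated at 16 ug/mL, with a range from 6 ug/mL to 40 ug/mL that is widened because the position and the core differ from the precedent.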

Compound 4, half-maximal inhibitory concentration: 18 ug/mL
Beside the measured number, compound 4's estimate is 1.1-fold (0.05 log units) below it, and the stated range covers the measured number.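

In this assay, chloro in place of hydrogen on an aromatic carbon of the nitro core gave a 1.2-fold higher number from compound 3 to compound 4 (0.08 log units; within the scatter), so the number of the nitro compound stays where it was within the scatter. Set beside the earlier step on the methoxy core, the new step does not differ from it, and on both cores the change leaves the number unresolved from that of its parent: the same change on two cores in this assay, a 1.4-fold higher number (0.14 log units; within the scatter) from compound 1 to compound 2 and a 1.2-fold higher number (0.08 log units; within the scatter) from compound 3 to compound 4, 1.1-fold (0.06 log units) apart, within the scatter of two such steps This does not show that one and the same change carries over, since the chloro of compound 4 sits on a five-membered aromatic ring with 1 nitrogen, next to the ring nitrogen, while that of compound 2 sits at another place on the shared core, and two pairs, each with a step within the scatter, cannot separate the influence of place from that of core.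

Going by these compounds, it remains open whether chloro at the place it holds in compound 4 would behave alike on the methoxy core, and whether chloro at the place it holds in compound 2 would do so on the nitro core. The compounds shown also leave open what an amine, a carboxylic acid or a longer chain would do at either of these places.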